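Cytotoxicity expected for compound 4 after a heteroaryl swap

The compounds below may be only part of what the source reports. "The series", "measured", "known", "first", "only" and "open" are said of these compounds alone.

Within the data shown here, compound 2 `CC(=O)N1CCC(C(=O)N(CCCN2CCC(CNC(=O)c3ccsc3)CC2)c2ccc(C)c(Cl)c2)CC1` is one of three compounds measured in an ADME assay (Homo sapiens) for cytotoxicity; a lower number here means that less compound is tolerated, a higher number that more compound is tolerated. In this assay compound 2 reaches only the limit > 51900 nM, as recorded in the limit of > 51900 nM in this assay, at which 1 of the 3 values shown sits. Compound 1 `CC(=O)N1CCC(C(=O)N(CCCN2CCC(CNC(=O)c3cnccn3)CC2)c2ccc(C)c(Cl)c2)CC1` likewise gives only the limit > 52400 nM. Compound 3 `CC(=O)N1CCC(C(=O)N(CCCN2CCN(Cc3ccc(S(C)(=O)=O)cc3)CC2)c2ccc(C)c(Cl)c2)CC1` gives only the limit > 49200 nM. Among the measured compounds shown here, the one measured step between neighbours, a step that the two limits leave unreadable from compound 1 to compound 2, is therefore of unreadable size. Compound 4 `CC(=O)N1CCC(C(=O)N(CCCN2CCC(CNc3cc(C)ccn3)CC2)c2ccc(C)c(Cl)c2)CC1` differs from compound 2 by 4-methylpyridin-2-yl in place of (thiophen-3-yl)carbonyl on an amine nitrogen. For the measured compounds named here, no measured step reads on this change, since a step that the two limits leave unreadable from compound 1 to compound 2 is hidden by the two limits; with all three values sitting at their limits, the expected outcome is a step no larger than the scatter, an at least 1.0-fold lower number from compound 2 to compound 4 (0.01 log units; that floor lies within the scatter). Compound 4 is accordingly estimated at 50000 nM, between 20000 nM and 120000 nM, most likely reported again only as a limit.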

Compound 4, half-maximal cytotoxic concentration: 17900 nM
Estimate against measurement, compound 4: 2.8-fold (0.45 log units) above, outside the stated range (below it).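

In this assay, among these compounds, 4-methylpyridin-2-yl on the amine nitrogen gives an at least 2.8-fold lower number from compound 2 to compound 4 (0.46 log units; beyond the scatter), and an at least 2.9-fold lower number from compound 1 to compound 4 (0.46 log units; beyond the scatter), so what this position carries can matter, which the earlier compounds could not show. The step between the two compounds that keep a carbonyl here cannot be read. Nothing measured here gives a cause for the lower number.

Going by these compounds, whether it follows from losing the carbonyl or from gaining the ring stays open, since compound 4 changes both at once. A pyridin-2-yl without the methyl, or a pyridin-2-ylcarbonyl on the same nitrogen, would bear on this.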